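This account rests on a few compounds, and the source may have more. Where it says the series, first, only, none or still open, it means among the compounds named here.

Compound 1 `N=C1S/C(=C\c2ccc(OCc3ccccc3)cc2)C(=O)N1c1ccccc1[N+](=O)[O-]` and compound 2 `N=C1S/C(=C\c2ccc(OCc3ccccc3)cc2)C(=O)N1c1ccccc1` share one core and differ in a single place. In an ADME assay on RAW264.7 cells (Mus musculus) for cytotoxicity, read by MTT assay, with a stated time of 48 h, tested at 50 uM (a lower number here means less inhibition, a higher number more inhibition at the concentration tested (going by the name of the read-out)), compound 1 gives 24.4%, while compound 2 gives 37.9%. For the measured compounds named here, the only measured step, a number 13.5 percentage points higher from compound 1 to compound 2 (beyond the scatter), concerns a nitro group and not the change considered next. On these two numbers compound 2 stands highest. Compound 3 `Cc1cccc(C)c1N1C(=N)S/C(=C\c2ccc(OCc3ccccc3)cc2)C1=O` differs from compound 2 by 2,6-dimethylphenyl in place of phenyl on an amide-type nitrogen in a ring. Going by the values given here, no measured step bears on this change, so no shift beyond the scatter is expected. Compound 3 is therefore estimated at 40%, between 25% and 55%. This corresponds to an expected step of a number 2.1 percentage points higher from compound 2 to compound 3 (within the scatter).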

Compound 3, a percentage reported as inhibition, at one concentration (the size of the read-out at that concentration, not a potency): 38.7%
Compound 3: middle estimate off by 1.3 percentage points, on the high side; the measured number falls inside the stated range.
By their numbers in this assay, from the lowest: compound 1; then compounds 2 and 3 (each within the scatter of the next).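

On the amide-type nitrogen in a ring, 2,6-dimethylphenyl and phenyl cannot be told apart in this assay, the step being a number 0.8 percentage points higher from compound 2 to compound 3 (within the scatter). Set against 2-nitrophenyl, 2,6-dimethylphenyl gives a number 14.3 percentage points higher from compound 1 to compound 3 (beyond the scatter), so among these three compounds only compound 1 , with its nitro group, stands apart. Nothing available explains either step. The compounds shown leave open how a 2-aminophenyl or 2-carboxyphenyl group at this position would read in this assay, and whether a longer chain on the nitrogen in place of the aromatic ring would give a similar number.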